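The source may hold more compounds than are shown below. What is called first, only, known or untested is meant among the compounds shown, and "the series" means these compounds.

Among the measured compounds shown here, compound 1 `COc1cccc(CNc2ncnc3c2ncn3C2CCCCO2)c1` is the only compound here with a measured number. In an ADME assay on K562 cells (Homo sapiens) for cytotoxicity, with a stated time of 72 h (a lower number here means a stronger inhibitor, a higher number a weaker inhibitor), compound 1 gives 61000 nM. Compound 2 `COc1ccc(CNc2ncnc3c2ncn3C2CCCCO2)cc1OC` is its closest measured relative. In this assay compound 2 reaches only a limit of the assay, > 100000 nM. On these data alone, the step of an at least 1.6-fold higher number from compound 1 to compound 2 (0.21 log units; that floor lies within the scatter) comes from a methoxy in place of hydrogen on an aromatic carbon, and its full size is unknown because of the limit of > 100000 nM in this assay, at which 1 of the 2 values shown sits. Compound 3 `COc1cc(CNc2ncnc3c2ncn3C2CCCCO2)cc(OC)c1` is not yet measured. For the measured compounds named here, it differs from compound 1 by methoxy in place of hydrogen on an aromatic carbon, a change of the same kind as the one from compound 1 to compound 2. Going by the values given here, that earlier step is the only guide: a further methoxy may again raise the number, though the floor of the measured step lies within the scatter. Compound 3 is expected to give 100000 nM, within a range from 45000 nM to 300000 nM. The expected step of a 1.6-fold higher number from compound 1 to compound 3 (0.21 log units; within the scatter) would thus be a weakening near the edge of the scatter, with a fair chance that only a limit is reported.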

Compound 3, half-maximal inhibitory concentration: > 100000 nM
Compound 3: only a limit was reported; the forecaster's own chance of this, stated with the estimate: 50%; the middle value lies on the limit itself.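

With the added methoxy now meta to a methoxy group, this assay shows an at least 1.6-fold higher number from compound 1 to compound 3 (0.21 log units; that floor lies within the scatter), so a second placement on the aromatic ring also gives no measurable number. Compound 3 reaches only a limit of the assay, > 100000 nM. Compound 2 and compound 3 carry their added methoxy in different places yet stop at the same limit, so the data cannot separate these two placements, and neither step can be shown to exceed the usual scatter: the limit of > 100000 nM in this assay, at which 2 of the 3 values shown sit.

On these data alone, how far compound 2 and compound 3 truly lie past that limit cannot be read, so the full size of both steps stays unknown. Also open, as far as these compounds go, is whether an amine, a carboxylic acid or a longer chain at this place on the ring would give a lower number than compound 1 does.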